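Cyclobutylmethyl to isobutyl: compound 3 to compound 4

The source may report more compounds than this note shows. Statements on the series, on what has been measured and on what is new or still open speak of the compounds shown alone.

Every reading so far in an ADME assay on Huh-7 cells (Homo sapiens) for cytotoxicity, with a stated time of 72 h (on this read-out lower numbers stand for higher toxicity in this test and higher numbers for lower toxicity in this test), is a limit, so the series offers no numerical value yet. Compound 1 (`CC(C)CCn1nc(-c2cccs2)c(O)c(C2=NS(=O)(=O)c3cc(NS(=O)(=O)C(C)C)ccc3N2)c1=O`) gives > 1000 nM as a limit. Compound 2 (`CC(C)CCn1nc(-c2cccs2)c(O)c(C2=NS(=O)(=O)c3cc(S(N)(=O)=O)ccc3N2)c1=O`) gives > 33000 nM as a limit. Compound 3 (`CS(=O)(=O)Nc1ccc2c(c1)S(=O)(=O)N=C(c1c(O)c(-c3cccs3)nn(CC3CCC3)c1=O)N2`) gives > 1000 nM as a limit, and this is where the step starts.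

Compound 4 (`CC(C)Cn1nc(-c2cccs2)c(O)c(C2=NS(=O)(=O)c3cc(NS(C)(=O)=O)ccc3N2)c1=O`) differs from compound 3 at one place: isopropyl in place of cyclobutyl on a saturated chain carbon bound to an aromatic nitrogen. In words, isopropyl stands in place of cyclobutyl on a saturated chain carbon bound to an aromatic nitrogen, which also reads as cyclobutylmethyl to isobutyl.

Among the measured compounds shown here, the only measured step is a step that the two limits leave unreadable from compound 1 to compound 2 in the series. It has no readable size and lies at another place, with sulfamoyl in place of (isopropylsulfonyl)amino on an aromatic carbon. For the measured compounds named here, no measured step covers the saturated chain, so the expectation in this assay is for no change beyond the scatter, with no direction favoured. The expected move is a step that the limit leaves unreadable from compound 3 to compound 4 on this estimate. For compound 4 the estimated value is 10000 nM with an expected range from 1500 nM to 40000 nM and a report as a limit is the likeliest outcome.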

Compound 4, half-maximal cytotoxic concentration: > 1000 nM
Compound 4: no number, only a limit; the forecaster's own chance of this, stated with the estimate: 85%; the middle value lies beyond the limit too.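

In this assay, compound 3 and compound 4 are both reported only as limits, and the step between them cannot be read. The compounds shown leave open whether cyclobutylmethyl and isobutyl differ at all in this assay, and at what numerical value any compound in the series would fall.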